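A few compounds are considered here, and "the series" means these few. Any claim that something is new, unique, unknown or untested is made for them only; others in the source may bear on it.

Measured so far in an in vivo ADME assay on the whole organism (strain Sprague-Dawley) for pharmacokinetics, with Rattus norvegicus as the target; on this read-out higher numbers stand for wider distribution into tissues and lower numbers for narrower distribution:

Compound 1 `CCCCCOC(=O)N1CCN(C(=O)[C@H](CCC(=O)O)NC(=O)c2cc(N3CCC(C(=O)N4CCCC4)CC3)nc(-c3ccccc3)n2)CC1` gives 0.2 L/kg.
Compound 2 `CCCCCOC(=O)N1CCN(C(=O)[C@H](CCC(=O)O)NC(=O)c2cc(N3CCC(OCCO)CC3)nc(-c3ccccc3)n2)CC1` gives 0.8 L/kg.
Compound 3 `CCCCCOC(=O)N1CCN(C(=O)[C@H](CCC(=O)O)NC(=O)c2nc(-c3ccccc3)cc(N3CCC(CN)CC3)n2)CC1` gives 0.28 L/kg.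

Compound 2 stands highest of the three numbers in this assay; compound 3 sits nearest to it, and compound 1 furthest, both gaps beyond the scatter. For the measured compounds named here, the one measured step that changes a single place runs from compound 1 to compound 2: a 4.0-fold higher number from compound 1 to compound 2 (0.60 log units; beyond the scatter), where a 2-hydroxyethoxy group replaced a (pyrrolidin-1-yl)carbonyl group on a saturated ring carbon.

Compound 4 `CCCCCOC(=O)N1CCN(C(=O)[C@H](CCC(=O)O)NC(=O)c2cc(N3CCC(C(N)=O)CC3)nc(-c3ccccc3)n2)CC1` is not yet measured. It differs from compound 2 in one place: carbamoyl in place of 2-hydroxyethoxy on a saturated ring carbon. The carbamoyl group that enters, like the (pyrrolidin-1-yl)carbonyl group of compound 1, carries a carbonyl on that ring carbon, so the step of compound 1 to compound 2 is the one that bears on this change, and it ran upward when the carbonyl group left. Running the other way, a downward step of about the same modest size is therefore expected from compound 2 to compound 4, a 2.7-fold lower number from compound 2 to compound 4 (0.43 log units; beyond the scatter), pulling the number back toward those of compound 1 and compound 3.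

Compound 4 is thus estimated at 0.3 L/kg in this assay, within a range of 0.15 L/kg to 0.7 L/kg.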

Compound 4, volume of distribution at steady state: 2.4 L/kg
Compound 4: middle estimate off by 8.0-fold (0.90 log units), on the low side; measured number above the stated range.
By their numbers in this assay, from the lowest: compounds 1 and 3 (each within the scatter of the next); then compound 2; then compound 4.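

In this assay, a carbonyl on this saturated ring carbon does not by itself go with a low number: with the carbonyl kept and only the group on it changed, amino in place of pyrrolidin-1-yl gives a 12-fold higher number from compound 1 to compound 4 (1.08 log units; beyond the scatter) and is the largest step in this set. The earlier rise from compound 1 to compound 2 therefore cannot be credited to the loss of the carbonyl alone, as the carbamoyl group keeps a carbonyl and still gives a 3.0-fold higher number from compound 2 to compound 4 (0.48 log units; beyond the scatter) on the same ring carbon. This carbon, three ring bonds from the ring nitrogen, thus moves the number widely across just three groups, which run from low to high as (pyrrolidin-1-yl)carbonyl, 2-hydroxyethoxy and carbamoyl.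

Still open, as far as these compounds go, is what happens between amino and pyrrolidin-1-yl: a methylamino or dimethylamino group on the same carbonyl would show whether the number falls gradually or abruptly, and a carboxylic acid on that ring carbon would pair the carbonyl with another partner. Nothing in the data at hand explains why the number moves this way.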